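This account rests on a few compounds, and the source may have more. Where it says the series, first, only, none or still open, it means among the compounds named here.

Working notes on the series.

Compound 3 `c1ccc(-c2nc3cccnc3o2)cc1` is the unsubstituted parent of this pair of cores. In a functional assay on the whole organism for inhibition, with Rattus norvegicus as the target, at a dose of 30 mg/kg (a lower number here means less inhibition, a higher number more inhibition at the dose given (going by the name of the read-out)), compound 3 gives 55%. Compound 1 `Fc1ccc(-c2nc3cccnc3o2)cc1` carries one more fluorine on the phenyl ring, and in this assay compound 1 gives 27%. The step is a number 28 percentage points lower from compound 3 to compound 1 (beyond the scatter), made by the change (fluoro in place of hydrogen on an aromatic carbon).

Compound 2 `Fc1ccc(-c2nc3ncccc3o2)cc1` has the other core; the difference between the two cores is not broken down here. In this assay compound 2 gives 28%, which is within the scatter of compound 1 and well below compound 3.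

Compound 4 `Fc1ccc(-c2nc3ncccc3o2)c(F)c1` is not yet measured. It differs from compound 2 by fluoro in place of hydrogen on an aromatic carbon. For the measured compounds named here, this is the same kind of change as the one from compound 3 to compound 1, but not the same: there the fluorine enters para to a group of 9 heavy atoms, here it enters ortho to a group of 9 heavy atoms and meta to a fluoro group. Going by the values given here, only one measured instance of this kind of change exists, and it sits on the other core, so the transfer is uncertain. Given that compound 2 already stands low, the step from compound 2 to compound 4 is expected to be modest, around a number 6 percentage points lower from compound 2 to compound 4 (within the scatter), resting on the downward direction seen in a number 28 percentage points lower from compound 3 to compound 1 (beyond the scatter). For compound 4 the expected inhibition in this assay is 22%, with a likely span from 5% to 40%.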

Compound 4, a percentage reported as inhibition, in the whole organism at one dose (the size of the read-out at that dose, not a potency): 23%
Estimate against measurement, compound 4: 1 percentage points below; low and high end bracket the measured number.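

In this assay, fluoro in place of hydrogen on an aromatic carbon does not carry over in size from one core to the other:  the same change on two cores in this assay, a number 28 percentage points lower (beyond the scatter) from compound 3 to compound 1 and a number 5 percentage points lower (within the scatter) from compound 2 to compound 4, 23 percentage points apart, beyond the scatter of two such steps

On the core of compound 2 the step reads a number 5 percentage points lower from compound 2 to compound 4 (within the scatter) and thus gives no readable change at this dose, so the clear drop seen on the core of compound 1 cannot be assumed for a second core in this series. What this does not show is that the core alone sets the gap: in compound 4 the fluorine enters ortho to a group of 9 heavy atoms and meta to a fluoro group, a different place from the step on the other core, and core and place vary together across just these two steps.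

The compounds shown leave open how the core of compound 2 behaves with no fluorine on the phenyl ring, and so whether a single fluorine placed as in compound 2 matters there at all. They also leave open what a group other than fluoro does on that ring, such as a chloro group, a methoxy group, an amine or a carboxylic acid, on either core.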